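Fluorine Added to a Weak Growth Inhibitor

A few compounds are considered here, and "the series" means these few. Any claim that something is new, unique, unknown or untested is made for them only; others in the source may bear on it.

Of the compounds shown here, three built on one shared core have been tested in a functional assay on PC-3 cells (Homo sapiens) for inhibition; a lower number here means a stronger inhibitor of growth, a higher number a weaker inhibitor of growth. Compound 1 `O=C(COc1ccc(/C=C2\SC(=O)NC2=O)cc1)Nc1ccc([N+](=O)[O-])cc1` carries a nitro group on its anilide. In this assay compound 1 gives > 100000 nM, which is a limit of the assay and not a number. Compound 2 `O=C(COc1ccc(/C=C2\SC(=O)NC2=O)cc1)Nc1ccc(Cl)cc1` carries a chloro group instead, and in this assay compound 2 gives 83400 nM. Compound 3 `O=C(COc1ccc(/C=C2\SC(=O)NC2=O)cc1)Nc1ccc(Br)cc1` carries a bromo group, and in this assay compound 3 gives 86600 nM. Of the two numbers shown, compound 3 has the higher one, but the step of a 1.0-fold higher number from compound 2 to compound 3 (0.02 log units; within the scatter) lies within the scatter, so the two cannot be told apart. The steps of an at least 1.1-fold lower number from compound 1 to compound 2 (0.07 log units; that floor lies within the scatter) and an at least 1.1-fold lower number from compound 1 to compound 3 (0.06 log units; that floor lies within the scatter) only set floors that also lie within the scatter.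

Compound 4 `O=C(COc1ccc(/C=C2\SC(=O)NC2=O)cc1)Nc1c(F)cc(Br)cc1F` has not yet been measured. It differs from compound 3 by 4-bromo-2,6-difluorophenyl in place of 4-bromophenyl on an amide-type nitrogen. Going by the values given here, no measured step adds fluorine; the one step that exchanges one halogen for another, a 1.0-fold higher number from compound 2 to compound 3 (0.02 log units; within the scatter), is within the scatter, and nothing measured points to a move beyond it. In this assay compound 4 is therefore expected to give 85000 nM, within a range from 35000 nM to 200000 nM. The expected step of a 1.0-fold lower number from compound 3 to compound 4 (0.01 log units; within the scatter) is estimated to be no larger than the scatter.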

Compound 4, concentration for 50% growth inhibition: > 100000 nM
Compound 4 ended at the assay's limit (the forecaster's own chance of this, stated with the estimate: 35%); middle value at least 1.1-fold (0.07 log units) away from the limit.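

In this assay compound 4 gives > 100000 nM, which is a limit of the assay and not a number. Going by these compounds alone, this is the first fluorine seen on the anilide ring, and the steps of an at least 1.1-fold higher number from compound 3 to compound 4 (0.06 log units; that floor lies within the scatter) and an at least 1.1-fold higher number from compound 2 to compound 4 (0.07 log units; that floor lies within the scatter) set only floors that lie within the scatter, so turning 4-bromophenyl into 4-bromo-2,6-difluorophenyl on the amide-type nitrogen brings no visible gain in growth inhibition, while no real loss can be read either. Compound 4 now stands with compound 1 at the limit, and the step between those two cannot be read: the limit of > 100000 nM in this assay, at which 2 of the 4 values shown sit.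

Still open, from the compounds shown here alone, is how far compound 4 truly lies from compound 3, and whether a single fluorine on the ring would behave as the pair does. Also open, going by these compounds, is whether any other group on the anilide, such as an amine or a carboxylic acid in place of the bromo group, would lift the shared core out of this weak range.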